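This account rests on a few compounds, and the source may have more. Where it says the series, first, only, none or still open, it means among the compounds named here.

Compound 1 `CC(C)[C@@H]1CC[C@@H](C)C[C@@]12N(C)C(=O)[C@@H]1[C@H]3C(=O)N(c4ccccc4)C(=O)[C@H]3ON12` stands lower of the two numbers shown in a functional assay, read by spectrophotometry, with a stated time of 2 h, tested at 2.5 mg/mL; on this read-out lower numbers stand for a weaker effect and higher numbers for a stronger effect at the one concentration tested: compound 1 gives 53.1%, while compound 2 `CC(C)[C@@H]1CC[C@@H](C)C[C@@]12N(C)C(=O)[C@@H]1[C@H]3C(=O)N(c4ccc(Cl)cc4)C(=O)[C@H]3ON12` gives 61.3%, with the step of a number 8.2 percentage points higher from compound 1 to compound 2 (within the scatter). Compound 3 `CC(C)[C@@H]1CC[C@@H](C)C[C@@]12N(C)C(=O)[C@@H]1[C@H]3C(=O)N(c4ccc5ccccc5c4)C(=O)[C@H]3ON12` differs from compound 1 by naphthalen-2-yl in place of phenyl on an amide-type nitrogen in a ring. Among the measured compounds shown here, no measured step covers a naphthalen-2-yl for phenyl swap; the only step in hand, from compound 1 to compound 2, concerns a different group and was within the scatter. Hence no step beyond the scatter is expected in this assay, in either direction. Compound 3 is estimated at 57%, range 40% to 73%, the expected step being a number 3.9 percentage points higher from compound 1 to compound 3 (within the scatter).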

Compound 3, a percentage reported as activity, at one concentration (the size of the read-out at that concentration, not a potency): 45.1%
For compound 3 the middle estimate is 11.9 percentage points above the measured one; the range from low to high includes it.
By their numbers in this assay, from the lowest: compounds 3, 1 and 2 (each within the scatter of the next, the first and the last beyond it).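

In this assay, among the compounds shown here, naphthalen-2-yl on the amide-type nitrogen gives a number 8 percentage points lower from compound 1 to compound 3 (within the scatter) when it replaces phenyl and a number 16.2 percentage points lower from compound 2 to compound 3 (beyond the scatter) when it replaces 4-chlorophenyl, the first step at this position to pass the scatter. The read-out at this position therefore does respond to the aryl group, but so far only in the comparison with 4-chlorophenyl. No measurement on hand bears on the reason for either step.

Open, going by these compounds, is whether a non-aromatic group such as cyclohexyl on this nitrogen holds the read-out. Also open, on these data alone, is how a phenyl carrying an amine or a carboxylic acid compares.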